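Fluoro in place of hydrogen on compound 2

The source may report more compounds than this note shows. Statements on the series, on what has been measured and on what is new or still open speak of the compounds shown alone.

Compound 1 `O=[N+]([O-])c1cc(C(F)(F)F)cc([N+](=O)[O-])c1Oc1ccccc1/C=N\OCc1ccccc1F`: 860 nM
Compound 2 `O=[N+]([O-])c1cc(C(F)(F)F)cc([N+](=O)[O-])c1Oc1ccc(Cl)cc1/C=N\OCc1ccccc1`: 3410 nM

In a functional assay on A549 cells (Homo sapiens) for antiproliferative activity, read by MTT assay, with a stated time of 48 h (on this read-out lower numbers stand for stronger inhibition and higher numbers for weaker inhibition), compound 2 gives 3410 nM as the higher of the two numbers, beyond the scatter from compound 1. The change to compound 3 `O=[N+]([O-])c1cc(C(F)(F)F)cc([N+](=O)[O-])c1Oc1ccc(Cl)cc1/C=N\OCc1ccccc1F` is fluoro in place of hydrogen on an aromatic carbon and turns benzyl to 2-fluorobenzyl. Within the data shown here, no measured pair isolates this change. Compound 1 carries 2-fluorobenzyl and gives 860 nM but also differs from compound 2 elsewhere, so a moderate fall in the number is expected, possibly within the scatter. For compound 3 the expected value is 1600 nM with an estimated range from 600 nM to 4000 nM on this read-out. The estimated step runs a 2.1-fold lower number from compound 2 to compound 3 (0.33 log units; beyond the scatter) in that direction.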

Compound 3, half-maximal inhibitory concentration: 2570 nM
Beside the measured number, compound 3's estimate is 1.6-fold (0.21 log units) below it, within the range that was stated.
By their numbers in this assay, from the lowest: compound 1; then compounds 3 and 2 (each within the scatter of the next).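

In this assay the 2-fluorobenzyl for benzyl change on the chloro-bearing core gives a step within the scatter (a 1.3-fold lower number from compound 2 to compound 3 (0.12 log units; within the scatter)), so no effect of fluoro can be read at this position in that setting. Among these compounds, with 2-fluorobenzyl held fixed, chloro in place of hydrogen gives the first single-place step beyond the scatter (a 3.0-fold higher number from compound 1 to compound 3 (0.48 log units; beyond the scatter)), which places the gap in this pair at the chloro site. No evidence bears on the cause of either step.

The compounds shown leave open whether the fluoro step reads the same on the core of compound 1, which lacks the chloro. Also open, on these data alone, is how a methoxy group or an amine would read at this place on the benzyl ring.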